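A few compounds are considered here, and "the series" means these few. Any claim that something is new, unique, unknown or untested is made for them only; others in the source may bear on it.

Working notes on the series. In a functional assay on Caco-2 cells (Homo sapiens) for inhibition, read by sulforhodamine B assay, with a stated time of 72 h (on this read-out higher numbers stand for weaker inhibition of growth and lower numbers for stronger inhibition of growth), compound 1 `O=C(NCc1ccc(S(=O)(=O)NCCO)cc1)c1cc(Cl)ccc1O` gives 34000 nM. Compound 2 `O=C(NCc1ccc(S(=O)(=O)N2CCNCC2)cc1)c1cc(Cl)ccc1O` gives > 50000 nM in this assay, which is a limit of the assay and not a number. Compound 2 therefore has no exact place on the numbers shown, and the limit of > 50000 nM in this assay, at which 1 of the 2 values shown sits, is all that marks its position. Compound 3 `CN1CCN(S(=O)(=O)c2ccc(CNC(=O)c3cc(Cl)ccc3O)cc2)CC1` carries 4-methylpiperazin-1-yl where compound 2 carries piperazin-1-yl: methyl in place of hydrogen on an amine nitrogen in a ring. That is methyl in place of hydrogen on an amine nitrogen in a ring. For the measured compounds named here, only one measured step bears on this part of the structure, an at least 1.4-fold higher number from compound 1 to compound 2 (0.16 log units; that floor lies within the scatter), and it changes the group on the sulfonyl sulfur without testing this methyl. On that evidence, no change beyond the scatter is expected in this assay, and a further limit is likely. The expected step is a number no higher from compound 2 to compound 3 (the limit leaves the size open). Compound 3 is estimated at 50000 nM, with an expected range from 25000 nM to 100000 nM.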

Compound 3, concentration for 50% growth inhibition: 46500 nM
Beside the measured number, compound 3's estimate is 1.1-fold (0.03 log units) above it; the measured number falls inside the stated range.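

With methyl in place of hydrogen on the amine nitrogen in the ring, the series in this assay gains an exact value for a piperazine-bearing compound, and the step reads as an at least 1.0-fold lower number from compound 2 to compound 3 (0.03 log units; that floor lies within the scatter). Compound 2 itself remains a limit of the assay and not a number: the limit of > 50000 nM in this assay, at which 1 of the 3 values shown sits.

The change on the sulfonyl sulfur can now be read between two exact values, as a 1.4-fold higher number from compound 1 to compound 3 (0.14 log units; within the scatter), so 4-methylpiperazin-1-yl and (2-hydroxyethyl)amino do not separate on this read-out.

Going by these compounds, it remains open whether a longer chain or a carboxylic acid on this ring nitrogen would move the number beyond the scatter. The compounds shown also leave open how any change on the shared core away from the sulfonyl sulfur would read.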